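This account rests on a few compounds, and the source may have more. Where it says the series, first, only, none or still open, it means among the compounds named here.

Measured so far in a functional assay on P815 cells (Mus musculus) for inhibition, read by microscopy and colony formation, with a stated time of 7 days, tested at 50 uM; a higher number here means a stronger effect of the compound at the concentration tested, a lower number a weaker effect:

compound 1, `COc1cc([C@H]2C=CC[C@@H]3C(=O)OC[C@@H]32)cc(OC)c1OC`, gives 178%
compound 2, `COc1cc([C@H]2C=CC[C@@H]3COC(=O)[C@H]32)cc(OC)c1OC`, gives 9%

Of these two numbers, compound 1 holds the higher one in this assay. The gap between compound 1 and compound 2 is far beyond the usual scatter of this kind of measurement. The two compounds differ in the way the lactone is built into the shared core, and nothing more can be said of that pair than what the two values show.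

Compound 3, `COc1cc([C@H]2C=CC[C@@H]3C(=O)OC[C@H]32)cc(OC)c1OC`, has not yet been measured. It is set apart from compound 1 only as follows: the two compounds have the same atoms and bonds and differ only in configuration as drawn: 1 of 3 stereo elements differ; a stereocentre at a saturated ring carbon is drawn R in compound 1 and S in compound 3. Because compound 1 gives 178% while its only measured companion gives a small number, a single inversion of configuration could leave much or little of the effect. The step is expected to run downward and to be a number 98 percentage points lower from compound 1 to compound 3 (beyond the scatter). Compound 3 is therefore estimated at 80%, within a wide range from 5% to 180%.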

Compound 3, a percentage reported as activity, at one concentration (the size of the read-out at that concentration, not a potency): 109%
For compound 3 the middle estimate is 29 percentage points below the measured one, and the stated range covers the measured number.
By their numbers in this assay, from the lowest: compound 2; then compound 3; then compound 1.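

In this assay, turning one saturated ring carbon from R to S gives a number 69 percentage points lower from compound 1 to compound 3 (beyond the scatter). This is the first pair shown that differs in one place only, and compound 3 still gives 109%, so this inversion lowers the read-out without abolishing it. The drop can be assigned to this single stereocentre because nothing else separates the two structures: the fact that compounds 1 and 3 differ only in the configuration as drawn

The compounds shown leave open what happens when either of the other two stereo elements is inverted on its own, since no pair isolates those changes. They also leave open how the read-out would respond if a methoxy group on the aromatic ring gave way to a hydroxyl group or an amine.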